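The source may report more compounds than this note shows. Statements on the series, on what has been measured and on what is new or still open speak of the compounds shown alone.

Working notes on the series, read in a functional assay on MDA-MB-231 cells (Homo sapiens) for antiproliferative activity, read by MTT assay, with a stated time of 24 h; a higher number here means a weaker inhibitor, a lower number a stronger inhibitor. Compound 1 (`O=C(O)CC(NC(=O)c1c(Cl)cccc1Cl)c1ccccc1`) gives > 100000 nM, which is a limit of the assay and not a number. Among the measured compounds shown here, compound 2 (`O=C(O)CC(NC(=O)c1ccc(Cl)cc1Cl)c1ccccc1`) gives 67200 nM, the only true number in the set so far. Compound 3 (`CC(C)(C)c1ccc(S(=O)(=O)NC(CC(=O)O)c2ccccc2)cc1`) gives > 100000 nM, again a limit of the assay and not a number. Compound 3 therefore has no number of its own and stands at the limit of > 100000 nM in this assay, at which 2 of the 3 values shown sit.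

Compound 4 (`N#Cc1ccc(S(=O)(=O)NC(CC(=O)O)c2ccccc2)cc1`) keeps the shared core of compound 3 and carries cyano in place of tert-butyl on an aromatic carbon, para to a large group: cyano in place of tert-butyl on an aromatic carbon.

For the measured compounds named here, no step between measured compounds is available to size this change, so the expectation rests on the standing of the set alone. Only compound 2 stands at 67200 nM, and no change beyond the scatter is expected in either direction. Most of the set sits at the limit of the assay, and a second limit is somewhat more likely than a number. The step expected in this assay is an at least 1.1-fold lower number from compound 3 to compound 4 (0.04 log units; that floor lies within the scatter), and it is an estimate measured against a limit. For compound 4 the estimated value is 90000 nM, with an expected range from 40000 nM to 200000 nM.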

Compound 4, half-maximal inhibitory concentration: 48700 nM
Compound 4: middle estimate off by 1.8-fold (0.27 log units), on the high side; measured number inside the range.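

Cyano in place of tert-butyl on an aromatic carbon, para to a large group, gives the first step that can be read in this series: in this assay it is an at least 2.0-fold lower number from compound 3 to compound 4 (0.31 log units; beyond the scatter) and shows that this position can move the read-out. The exchange replaces 4 heavy atoms, all carbon and with no hydrogen-bond acceptor, with 2 heavy atoms that include 1 hydrogen-bond acceptor and a triple bond, so a true number is now available for a compound with this shared core. Going by these compounds, the step can be given only as a floor, and its full size stays unknown, because compound 3 has only a limit: the limit of > 100000 nM in this assay, at which 2 of the 4 values shown sit.

This single exchange changes group size, atom type and acceptor count together, so the compounds shown do not tell which of these differences goes with the lower number. On these data alone, an amine or a methoxy group at the same position would test whether the step depends on cyano itself, and the true distance from tert-butyl remains open.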